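The source may report more compounds than this note shows. Statements on the series, on what has been measured and on what is new or still open speak of the compounds shown alone.

Of the compounds shown here, two with a shared core have been measured in a functional assay on A549 cells (Homo sapiens) for antiproliferative activity, read by MTT assay; a higher number here means a weaker inhibitor, a lower number a stronger inhibitor. In this test, compound 1 `Cn1c(=O)c(=O)n(C2CCCC2)c2nc(N/N=C/c3cccc(Cl)c3Cl)ncc21`, which carries 2,3-dichlorophenyl, gives 39100 nM. Compound 2 `Cc1ccc(/C=N/Nc2ncc3c(n2)n(C2CCCC2)c(=O)c(=O)n3C)cc1C`, which carries 3,4-dimethylphenyl, gives 30200 nM, and so stands level with compound 1 within the scatter. Neither can be placed ahead of the other.

Compound 3 `Cn1c(=O)c(=O)n(C2CCCC2)c2nc(N/N=C/c3cccc(O)c3)ncc21` has not yet been measured. It differs from compound 2 in one place: 3-hydroxyphenyl in place of 3,4-dimethylphenyl on a carbon with a double bond to nitrogen. For the measured compounds named here, the only measured step that bears on this change is a 1.3-fold lower number from compound 1 to compound 2 (0.11 log units; within the scatter), which also exchanged one substituted phenyl group for another on the carbon with a double bond to nitrogen. That step is a limited guide, since neither compound 1 nor compound 2 carries a hydroxy group, and the data hold no direct comparison for 3-hydroxyphenyl. No shift beyond the scatter is therefore expected, with the estimated step being a 1.1-fold lower number from compound 2 to compound 3 (0.03 log units; within the scatter). The uncertainty remains wide in both directions. For compound 3 the expected value is 28000 nM, with an estimated range from 10000 nM to 70000 nM.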

Compound 3, half-maximal inhibitory concentration: > 100000 nM
Compound 3 was reported as a limit (the forecaster's own chance of this, stated with the estimate: 10%); at least 3.5-fold (0.55 log units) between middle value and limit.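

The carbon with a double bond to nitrogen proved sensitive to the choice of aryl group. The exchange between 2,3-dichlorophenyl and 3,4-dimethylphenyl had stayed within the scatter, but in this assay 3-hydroxyphenyl brings an at least 3.3-fold higher number from compound 2 to compound 3 (0.51 log units; beyond the scatter), and likewise an at least 2.5-fold higher number from compound 1 to compound 3 (0.40 log units; beyond the scatter). Unlike 3,4-dimethylphenyl, 3-hydroxyphenyl counts a hydrogen-bond donor and a hydrogen-bond acceptor, although nothing here ties that difference to the result, and the value of compound 3 is a limit rather than a number: the limit of > 100000 nM in this assay, at which 1 of the 3 values shown sits.

Since this single exchange both adds the hydroxy group and removes the two methyl groups, the compounds shown do not tell which of these goes with the higher number. Also open, from the compounds shown here alone, is how a methoxy group, an amine or a carboxylic acid on the phenyl ring would read in this assay, and whether any group at this place could give a number clearly lower than those of compound 1 and compound 2.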